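Oxan-4-yl for cyclohexylmethyl on the imidazole ring nitrogen

The source may hold more compounds than are shown below. What is called first, only, known or untested is meant among the compounds shown, and "the series" means these compounds.

Measured compounds:
compound 1 `c1ccc(Cn2cnc3c(-c4ccco4)ncnc32)cc1` — 59 ug/mL
compound 2 `c1coc(-c2ncnc3c2ncn3CC2CCCCC2)c1` — 60 ug/mL

In a functional assay on K562 cells (Homo sapiens), read by thymidine incorporation (on this read-out lower numbers stand for stronger inhibition and higher numbers for weaker inhibition), compound 1 gives 59 ug/mL and compound 2 gives 60 ug/mL. Among the measured compounds shown here, compound 2 and compound 1 stand within the scatter of each other, as the single measured step shows: a 1.0-fold higher number from compound 1 to compound 2 (0.01 log units; within the scatter). That step touches the same position as the change now considered. Compound 3 `c1coc(-c2ncnc3c2ncn3C2CCOCC2)c1` differs from compound 2 by oxan-4-yl in place of cyclohexylmethyl on an aromatic nitrogen. For the measured compounds named here, no measured step covers this exact change; the one step at this position was flat, so compound 3 is expected to show a 1.2-fold higher number from compound 2 to compound 3 (0.07 log units; within the scatter). Compound 3 is estimated at 70 ug/mL, with a range from 30 ug/mL to 160 ug/mL.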

Compound 3, half-maximal inhibitory concentration: 15 ug/mL
Beside the measured number, compound 3's estimate is 4.7-fold (0.67 log units) above it, outside the stated range (below it).
By their numbers in this assay, from the lowest: compound 3; then compounds 1 and 2 (each within the scatter of the next).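

Benzyl and cyclohexylmethyl had left this position looking flat, but in this assay it proves responsive, with a 4.0-fold lower number from compound 2 to compound 3 (0.60 log units; beyond the scatter) and a 3.9-fold lower number from compound 1 to compound 3 (0.59 log units; beyond the scatter) as the two steps to oxan-4-yl. The change replaces a ring carbon with oxygen and also removes the saturated chain carbon that linked the ring to the aromatic nitrogen, so the two alterations travel together. Nothing available accounts for the step.

The compounds shown leave open which alteration carries the step. Cyclohexyl bound directly to the aromatic nitrogen and oxan-4-ylmethyl would separate the two, and piperidin-4-yl remains open as well.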